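The source may hold more compounds than are shown below. What is called first, only, known or untested is meant among the compounds shown, and "the series" means these compounds.

Of the compounds shown here, two have numbers so far. In a functional assay on RPMI-8226 cells (Homo sapiens) for inhibition, with a stated time of 48 h (on this read-out higher numbers stand for weaker inhibition of growth and lower numbers for stronger inhibition of growth), compound 1 (`COc1c(C(=O)/C=C/c2ccc(Cl)cc2)c(O)c(Br)c2occc12`) gives 2780 nM and compound 2 (`C=CCc1c(O)c(C(=O)/C=C/c2ccccc2)c(OC)c2ccoc12`) gives 1880 nM on the same read-out. These two values lie within the usual scatter of repeated measurements, so they cannot be told apart. Compound 3 (`C=CCc1c(O)c(C(=O)/C=C/c2ccc(Cl)cc2)c(OC)c2ccoc12`) is compound 2 with one change (chloro in place of hydrogen on an aromatic carbon), turning phenyl to 4-chlorophenyl. Among the measured compounds shown here, no measured pair here shows this change alone, so the expectation in this assay rests on the small size of the change and on compound 2 as the starting point. A slight shift toward stronger inhibition of growth is expected, and the estimated 1.2-fold lower number from compound 2 to compound 3 (0.07 log units; within the scatter) stays within the scatter. For compound 3 the estimated value is 1600 nM with an expected range from 700 nM to 3600 nM in this test.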

Compound 3, concentration for 50% growth inhibition: 3040 nM
The estimate for compound 3 lay 1.9-fold (0.28 log units) below the measured number; the measured number falls inside the stated range.
By their numbers in this assay, from the lowest: compounds 2, 1 and 3 (each within the scatter of the next).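

In this assay, putting chloro in place of hydrogen, para to a large group on the six-membered aromatic ring, gives a 1.6-fold higher number from compound 2 to compound 3 (0.21 log units; within the scatter) and so shows that this single added chlorine produces no difference that can be told apart from repeat-measurement scatter. With 4-chlorophenyl held in place on both compounds, allyl in place of bromo on an aromatic carbon of the core gives a 1.1-fold higher number from compound 1 to compound 3 (0.04 log units; within the scatter) and likewise cannot be told apart from scatter. Nothing available explains either result.

On these data alone, whether an amine or a carboxylic acid at the para place of this ring would move the number beyond the scatter remains open. Also open, as far as these compounds go, is whether a longer chain in place of allyl would do so.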